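The compounds below may be only part of what the source reports. "The series", "measured", "known", "first", "only" and "open" are said of these compounds alone.

Three compounds of one shared core have been examined in a functional assay on HT-29 cells (Homo sapiens) for inhibition, read by sulforhodamine B assay, with a stated time of 48 h (on this read-out higher numbers stand for lower toxicity in this test and lower numbers for higher toxicity in this test), and the account that follows turns on a fourth member of the series. Compound 1 `CCOC(=O)[C@H](CCC(=O)O)NC(=O)c1ccc(CNc2nc3cc(N)cc(N)c3nc2-c2ccccc2)cc1` carries a glutamate-bearing benzamide linked through a methylene amine to the core. In this assay compound 1 gives < 100000 nM, which is a limit of the assay rather than a number. Compound 2 `COc1ccc(CNc2nc3cc(N)cc(N)c3nc2-c2ccccc2)cc1OC` carries a dimethoxybenzyl amine on the same core. In this assay compound 2 gives < 100000 nM, again a limit of the assay and not a measured number. Compound 3 `CCOC(=O)[C@H](CCC(=O)O)NC(=O)c1ccc(Sc2nc3cc(N)cc(N)c3nc2-c2ccccc2)cc1` is the thioether counterpart of compound 1. In this assay compound 3 gives < 100000 nM, once more a limit of the assay. Among the measured compounds shown here, no step between measured compounds can therefore be read, and the only pattern in the values is the limit of < 100000 nM in this assay, at which 3 of the 3 values shown sit. Compound 4 `COc1cc(CNc2nc3cc(N)cc(N)c3nc2-c2ccccc2)cc(OC)c1OC` is the unmeasured one; it differs from compound 2 by methoxy in place of hydrogen on an aromatic carbon. With every measured value sitting at the limit, no step beyond the scatter is expected, and the author expects the step from compound 2 to compound 4 to be a step that the limit leaves unreadable from compound 2 to compound 4. For compound 4 the expected value in this assay is 30000 nM, within a range from 5000 nM to 100000 nM.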

Compound 4, concentration lethal to 50% of the cells: 43700 nM
Compound 4: the middle estimate sits 1.5-fold (0.16 log units) below what was measured; the measured number falls inside the stated range.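

No step from compound 2 to compound 4 can be read, as compound 2 stands in this assay only as a limit of the assay: the limit of < 100000 nM in this assay, at which 3 of the 4 values shown sit.

The compounds shown leave open whether methoxy in place of hydrogen on an aromatic carbon shifts the lethal concentration in this assay at all, and by how much.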